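Loss of the hydroxymethyl group tested a second time

The source may hold more compounds than are shown below. What is called first, only, known or untested is meant among the compounds shown, and "the series" means these compounds.

Three compounds of the series have numbers in a functional assay on cells (Homo sapiens) for cytotoxicity, read by sulforhodamine B assay, with a stated time of 2 days; on this read-out higher numbers stand for weaker inhibition and lower numbers for stronger inhibition. Compound 3 `CN(C)c1ccc(-c2nc3c(s2)C(O)CNC3)c(CO)c1` gives 100 nM, compound 1 `CN(C)c1ccc(-c2nc3c(s2)C(O)CNC3)cc1` gives 1630 nM, and compound 2 `OCc1cc(N2CCCC2)ccc1-c1nc2c(s1)C(O)CCC2` gives 44 nM, the lowest of the three. For the measured compounds named here, only one single-point change has been measured so far: hydrogen in place of hydroxymethyl on an aromatic carbon. That change produced a 16-fold higher number from compound 3 to compound 1 (1.21 log units; beyond the scatter), a large step. Compound 4 `OC1CCCc2nc(-c3ccc(N4CCCC4)cc3)sc21` carries the same kind of change applied to compound 2: hydrogen in place of hydroxymethyl on an aromatic carbon. The surroundings are not identical, since the place in compound 4 is meta to a pyrrolidin-1-yl group whereas that in compound 1 is meta to a dimethylamino group, and the difference between the cores of compound 2 and compound 3 is not broken down here. With one precedent, the expectation for compound 4 in this assay is a step of about a 14-fold higher number from compound 2 to compound 4 (1.13 log units; beyond the scatter), resting on a 16-fold higher number from compound 3 to compound 1 (1.21 log units; beyond the scatter) and allowing for the changed surroundings. Compound 4 is accordingly estimated at 600 nM, within a range from 200 nM to 1800 nM.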

Compound 4, half-maximal inhibitory concentration: 2800 nM
Beside the measured number, compound 4's estimate is 4.7-fold (0.67 log units) below it, and the stated range ends below it.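

In this assay, replacing the hydroxymethyl group with hydrogen on the second core again gives a higher number, with a 64-fold higher number from compound 2 to compound 4 (1.80 log units; beyond the scatter), so the direction of the change carries over between these two cores. The size of the step does not carry over: the same change on two cores in this assay, a 16-fold higher number (1.21 log units; beyond the scatter) from compound 3 to compound 1 and a 64-fold higher number (1.80 log units; beyond the scatter) from compound 2 to compound 4, 3.9-fold (0.59 log units) apart, beyond the scatter of two such steps These two pairs do not separate the contribution of the core from that of the pyrrolidin-1-yl group standing where the other pair has a dimethylamino group, and they give no rule for a third core.

Open is whether the hydroxymethyl group is specifically required, since the compounds shown include no methoxymethyl, hydroxyethyl, aminomethyl or carboxylic acid group at that place. Also open, as far as these compounds go, is how the two steps would compare with the amine group exchanged between the cores, with the dimethylamino group on the core of compound 2 and the pyrrolidin-1-yl group on the core of compound 3.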